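This account rests on a few compounds, and the source may have more. Where it says the series, first, only, none or still open, it means among the compounds named here.

Measured so far, all in an assay on isolated protein for inhibition of Maltase-glucoamylase (Homo sapiens), with a stated time of 15 min; on this read-out higher numbers stand for weaker inhibition and lower numbers for stronger inhibition:

compound 1, `O=C(N/N=C/c1ccc(O)cc1)c1ccc(-c2nc3ccccc3s2)cc1`: 11300 nM
compound 2, `O=C(N/N=C/c1cccc(O)c1O)c1ccc(-c2nc3ccccc3s2)cc1`: 11200 nM
compound 3, `COc1ccc(/C=N/NC(=O)c2ccc(-c3nc4ccccc4s3)cc2)c(O)c1`: 6970 nM

Compound 3 gives the lowest of the three numbers, but its steps to the other two, a 1.6-fold lower number from compound 1 to compound 3 (0.21 log units; within the scatter) and a 1.6-fold lower number from compound 2 to compound 3 (0.21 log units; within the scatter), both sit within the scatter, so no order among compounds 1, 2 and 3 can be read from these numbers. The step from compound 1 to compound 2 likewise shows no change: a 1.0-fold lower number from compound 1 to compound 2 (0.00 log units; within the scatter).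

Compound 4, `O=C(N/N=C/c1ccc([N+](=O)[O-])cc1)c1ccc(-c2nc3ccccc3s2)cc1`, is not yet measured. Its difference from compound 3 is 4-nitrophenyl in place of 2-hydroxy-4-methoxyphenyl on a carbon with a double bond to nitrogen. All three measured steps bear on it, since each exchanges the aryl group on that same carbon with a double bond to nitrogen, and none of them moved the number beyond the scatter. Nothing here gives a reason to expect that the 4-nitrophenyl should behave differently, so the expected step in this assay is none beyond the scatter: a 1.2-fold higher number from compound 3 to compound 4 (0.09 log units; within the scatter).

Compound 4 is therefore estimated at 8500 nM, with a range of 3500 nM to 20000 nM.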

Compound 4, half-maximal inhibitory concentration: 26400 nM
For compound 4 the middle estimate is 3.1-fold (0.49 log units) below the measured one; measured number outside the range, above it.
By their numbers in this assay, from the lowest: compounds 3, 2 and 1 (each within the scatter of the next); then compound 4.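

In this assay the aryl group on the carbon with a double bond to nitrogen is no longer silent: 4-nitrophenyl gives the first exchanges there that go beyond the scatter, namely a 3.8-fold higher number from compound 3 to compound 4 (0.58 log units; beyond the scatter) and a 2.4-fold higher number from compound 2 to compound 4 (0.37 log units; beyond the scatter) and, as nitro in place of hydroxy on an aromatic carbon, a 2.3-fold higher number from compound 1 to compound 4 (0.37 log units; beyond the scatter) (all three in the same direction). Among these four compounds, 4-nitrophenyl is also the only aryl group without a hydrogen-bond donor, so the three hydroxy-bearing aryl groups, indistinguishable from one another, stand apart from it as a set. Nothing available explains this step.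

As far as these compounds go, whether the step follows from losing hydroxy or from gaining nitro stays open, and plain phenyl, 4-aminophenyl or 4-carboxyphenyl at this carbon would help separate the two. Whether the same step holds with any other core is also unknown.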